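Fluorines replace trifluoromethyl on the second aryl ring

The source may report more compounds than this note shows. Statements on the series, on what has been measured and on what is new or still open speak of the compounds shown alone.

Of the compounds shown here, three sharing one core have been measured in a functional assay on CHO cells for antagonist activity at transient receptor potential cation channel subfamily V member 1 (Rattus norvegicus), read by calcium flux; a higher number here means a weaker inhibitor, a lower number a stronger inhibitor. Compound 1 `FC(F)(F)c1cccc(-c2[nH]c(N3CCN(c4ncccc4C(F)(F)F)CC3)nc2-c2ccccc2)c1` gives 1240 nM, compound 3 `Fc1cc(F)cc(-c2nc(N3CCN(c4ncccc4C(F)(F)F)CC3)[nH]c2-c2ccc(C(F)(F)F)cc2)c1` gives 35 nM, and compound 2 `Fc1cc(-c2nc(N3CCN(c4ncccc4C(F)(F)F)CC3)[nH]c2-c2ccc(C(F)(F)F)cc2)cc(F)c1F` gives 7 nM, the lowest of the three numbers. For the measured compounds named here, the one single-point step recorded is a 5.0-fold higher number from compound 2 to compound 3 (0.70 log units; beyond the scatter), and it concerns the other aryl ring, not the one changed here. Compound 4 `Fc1cc(-c2nc(N3CCN(c4ncccc4C(F)(F)F)CC3)[nH]c2-c2cc(F)c(F)c(F)c2)cc(F)c1F` differs from compound 2 by 3,4,5-trifluorophenyl in place of 4-(trifluoromethyl)phenyl on an aromatic carbon. Going by the values given here, no measured step touches this ring, so the expectation rests only on the modest loss seen when a fluoro is removed elsewhere. Compound 4 is therefore expected to stay close to compound 2, giving an estimated 15 nM (range 4 nM to 60 nM), a step of a 2.1-fold higher number from compound 2 to compound 4 (0.33 log units; beyond the scatter).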

Compound 4, half-maximal inhibitory concentration: 44 nM
Compound 4: the middle estimate sits 2.9-fold (0.47 log units) below what was measured; measured number inside the range.
By their numbers in this assay, from the lowest: compound 2; then compounds 3 and 4 (each within the scatter of the next); then compound 1.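

In this assay, replacing 4-(trifluoromethyl)phenyl with 3,4,5-trifluorophenyl gives a 6.3-fold higher number from compound 2 to compound 4 (0.80 log units; beyond the scatter), a step beyond the scatter. The earlier single-point step concerned only the other aryl ring, so this shows that the number also responds to the group at this position, and that this trifluorinated ring does not match the group it replaces. Nothing available explains this loss. The compounds shown leave open how a chloro, methoxy or nitrile group on this ring would compare with 4-(trifluoromethyl)phenyl.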